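The compounds below may be only part of what the source reports. "The series", "measured", "known", "first", "only" and "open" are said of these compounds alone.

Of the compounds shown here, three built on one shared core have been tested in an ADME assay on HEK293 cells (Homo sapiens) for cytotoxicity, with a stated time of 72 h; on this read-out higher numbers stand for an effect only at larger amounts of compound and lower numbers for an effect already at smaller amounts. Compound 1 `CCc1ccc(NC(=O)Nc2cc(C)nc3ccccc23)cc1` gives 16000 nM, and compound 2 `Cc1cc(NC(=O)Nc2ccc(SC(F)(F)F)cc2)c2ccccc2n1` gives 13000 nM. Compound 3 `Cc1cc(NC(=O)Nc2ccc(C(=O)O)cc2)c2ccccc2n1` has no exact number, only a limit of the assay, > 25000 nM. Its place on the scale is therefore (the limit of > 25000 nM in this assay, at which 1 of the 3 values shown sits).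

Compound 4 `Cc1cc(NC(=O)Nc2ccc(C(=O)O)c(O)c2)c2ccccc2n1` differs from compound 3 by a single change: hydroxy in place of hydrogen on an aromatic carbon. This is hydroxy in place of hydrogen on an aromatic carbon, ortho to a carboxy group and meta to a large group.

Among the measured compounds shown here, no measured step makes this exact change, so the nearest guides are swaps of one group on an aromatic carbon. These are a 1.2-fold lower number from compound 1 to compound 2 (0.09 log units; within the scatter), an at least 1.5-fold higher number from compound 1 to compound 3 (0.19 log units; that floor lies within the scatter) and an at least 1.9-fold higher number from compound 2 to compound 3 (0.28 log units; that floor lies within the scatter). On these data alone, the last two are only floors, so their true sizes remain open. None of the three is shown to go beyond the scatter, so no step beyond the scatter is expected in this assay, and the reading may again be only a limit. The expected change is a step that the limit leaves unreadable from compound 3 to compound 4. For compound 4 the estimated value is 28000 nM, with an expected range of 14000 nM to 56000 nM.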

Compound 4, half-maximal effective concentration in the HEK293 assay: > 25000 nM
Compound 4 was reported as a limit; the forecaster's own chance of this, stated with the estimate: 70%; the middle value is on the limit's open side.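

In the HEK293 assay compound 3 is reported only as a limit of the assay, > 25000 nM. In the HEK293 assay compound 4 is also reported only as a limit of the assay, > 25000 nM. Among the compounds shown here, no step between them can be read. The compounds shown leave open at what amount either compound would act on these cells, and whether hydroxy in place of hydrogen on an aromatic carbon changes that amount. In a physicochemical assay for solubility, at pH 7.4 (a lower number here means a less soluble compound, a higher number a more soluble compound), compound 3 gives 9300 nM and compound 4 gives 26600 nM.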